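Swapping the Carboxyphenyl Amide for a Lactam Chain

The source may report more compounds than this note shows. Statements on the series, on what has been measured and on what is new or still open speak of the compounds shown alone.

Within the data shown here, compound 2 `C=C(CC)C(=O)c1ccc(OCC(=O)Nc2ccc(C(=O)O)cc2)c(Cl)c1Cl` gives 5000 nM in a functional assay on CLL cells (Homo sapiens) for cytotoxicity, read by MTT assay, with a stated time of 48 h (on this read-out higher numbers stand for an effect only at larger amounts of compound and lower numbers for an effect already at smaller amounts), which stands highest of the three numbers so far, although compound 1 `C=C(CC)C(=O)c1ccc(OCC(=O)Nc2ccc(C(=O)OC)cc2)c(Cl)c1Cl` with 4100 nM and compound 3 `C=C(CC)C(=O)c1ccc(OCC(=O)Nc2ccc(CC(=O)O)cc2)c(Cl)c1Cl` with 3200 nM both lie within the scatter of it. Compound 4 `C=C(CC)C(=O)c1ccc(OCC(=O)NCCCN2CCCC2=O)c(Cl)c1Cl` differs from compound 2 by 3-(2-oxopyrrolidin-1-yl)propyl in place of 4-carboxyphenyl on an amide-type nitrogen. The measured steps, a 1.2-fold higher number from compound 1 to compound 2 (0.09 log units; within the scatter), a 1.3-fold lower number from compound 1 to compound 3 (0.11 log units; within the scatter) and a 1.6-fold lower number from compound 2 to compound 3 (0.19 log units; within the scatter), all vary only the group on that same amide nitrogen and all stay within the scatter, yet none of them removes the aromatic ring, so they bear on this change only loosely. No step beyond the scatter is therefore expected for compound 4 in this assay, with wide uncertainty. Compound 4 is estimated at 5000 nM, in the range 1500 nM to 16000 nM, which means an expected step of no change at the digits printed from compound 2 to compound 4 (within the scatter).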

Compound 4, half-maximal effective concentration: 13800 nM
Estimate against measurement, compound 4: 2.8-fold (0.44 log units) below; the measured number falls inside the stated range.
By their numbers in this assay, from the lowest: compounds 3, 1 and 2 (each within the scatter of the next); then compound 4.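

In this assay, among these compounds, the change from 4-carboxyphenyl to 3-(2-oxopyrrolidin-1-yl)propyl gives a 2.8-fold higher number from compound 2 to compound 4 (0.44 log units; beyond the scatter) and is the first change on this amide-type nitrogen to go beyond the scatter. This shows that the group held there can shift the number, at least when the aromatic ring is lost. Nothing measured here gives a cause for the step.

As far as these compounds go, the change swaps the aromatic ring and the chain together, so their shares stay open. A propyl chain ending in a carboxylic acid, or a phenyl ring carrying 2-oxopyrrolidin-1-yl, would separate them.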